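Swapping a chlorophenyl for a nitrophenyl: expected lipophilicity

This account rests on a few compounds, and the source may have more. Where it says the series, first, only, none or still open, it means among the compounds named here.

Compound 1 `CCOC(=O)C1=C(C)NC(=S)NC1c1cn(C(=O)CNc2ccccc2Cl)c2ccccc12` is the most lipophilic of the three measured compounds: in a physicochemical assay for lipophilicity (a lower number here means a more polar compound, a higher number a more lipophilic compound), compound 1 gives 3.44, while compound 3 `CCOC(=O)C1=C(C)NC(=O)NC1c1cn(C(=O)CNc2ccc(Cl)cc2)c2ccccc12` gives 2.04 and compound 2 `CCOC(=O)C1=C(C)NC(=O)NC1c1cn(C(=O)CNc2cccc([N+](=O)[O-])c2)c2ccccc12` gives 1.48. Among the compounds with values here, compound 1 differs from both of these in more than one place, so no single measured step links it to them. Compound 4 `CCOC(=O)C1=C(C)NC(=S)NC1c1cn(C(=O)CNc2ccc([N+](=O)[O-])cc2)c2ccccc12` is compound 1 with one change: 4-nitrophenyl in place of 2-chlorophenyl on an amine nitrogen. Within the data shown here, the one measured step that bears on this runs the other way, from a nitrophenyl to a chlorophenyl: a number 0.56 log units higher from compound 2 to compound 3 (beyond the scatter). Reversing that, a modest fall is expected here, with added uncertainty since the groups do not match exactly. Compound 4 is therefore estimated at 2.85, between 2.3 and 3.4, a step of a number 0.59 log units lower from compound 1 to compound 4 (beyond the scatter).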

Compound 4, partition coefficient: 2.88
The estimate for compound 4 lay 0.03 log units below the measured number; the range from low to high includes it.
By their numbers in this assay, from the lowest: compound 2; then compound 3; then compound 4; then compound 1.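

In this assay, 4-nitrophenyl in place of 2-chlorophenyl on the amine nitrogen gives a number 0.56 log units lower from compound 1 to compound 4 (beyond the scatter) and so puts the nitrophenyl partner lower in a second pair, one built on a different core. Its size matches a number 0.56 log units higher from compound 2 to compound 3 (beyond the scatter) even though the groups differ. Nothing here gives a measured reason for this.

On these data alone, the effect of where each group sits on its ring stays open: this pair sets 2-chlorophenyl against 4-nitrophenyl, the earlier one 4-chlorophenyl against 3-nitrophenyl. So does the result for plain phenyl or a phenyl carrying a carboxylic acid on this nitrogen.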